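This account rests on a few compounds, and the source may have more. Where it says the series, first, only, none or still open, it means among the compounds named here.

Compound 3 `CC(C)(N)C(=O)N[C@H](COCc1ccccc1)c1nnn(Cc2ccccc2)n1` is measured in a functional assay on H4 cells for agonist activity at growth hormone secretagogue receptor type 1 (Homo sapiens), read by FLIPR (a lower number here means that less compound is needed, a higher number that more compound is needed for the effect), where compound 3 gives 1120 nM. That is the highest number of the three known. Compound 2 `COC(=O)C(c1ccccc1)n1nnnc1[C@@H](COCc1ccccc1)NC(=O)C(C)(C)N` gives in this assay 20 nM, and compound 1 `CN(c1ccccc1CCCn1nnnc1[C@@H](COCc1ccccc1)NC(=O)C(C)(C)N)S(C)(=O)=O` gives 14 nM; both of these numbers lie below that of compound 3 by gaps beyond the usual scatter, compound 2 being the nearer and compound 1 the further of the two.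

Compound 4 `CC(C)(N)C(=O)N[C@H](COCc1ccccc1)c1nnn(Cc2cccc(NS(C)(=O)=O)c2)n1` is not yet measured in this assay. It differs from compound 3 by methanesulfonamido in place of hydrogen on an aromatic carbon. For the measured compounds named here, no pair among the measured compounds shows this change on its own, so its size cannot be read from the record. Given that compound 3 stands at 1120 nM, the weakest position shown, the step from compound 3 to compound 4 is expected to lower the number modestly, by a 2.8-fold lower number from compound 3 to compound 4 (0.45 log units; beyond the scatter), though a result within the scatter would not be surprising. Compound 4 is therefore estimated at 400 nM, with a likely range from 100 nM to 1600 nM.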

Compound 4, half-maximal effective concentration: 868 nM
Compound 4: middle estimate off by 2.2-fold (0.34 log units), on the low side; low and high end bracket the measured number.
By their numbers in this assay, from the lowest: compounds 1 and 2 (each within the scatter of the next); then compounds 4 and 3 (each within the scatter of the next).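

In this assay, for the compounds shown here, the step reads as a 1.3-fold lower number from compound 3 to compound 4 (0.11 log units; within the scatter) and is the only single-place step on record, so the methanesulfonamido group, placed meta to a large group, gives no number that can be told apart from the parent. Compound 3 at 1120 nM and compound 4 at 868 nM therefore stand together, and at this place the phenyl to 3-(methanesulfonamido)phenyl change shows no measurable effect on the number in this assay. No accompanying measurement bears on this result.

As far as these compounds go, whether an amine or a carboxylic acid at this same place, or methanesulfonamido at another carbon of the ring, would move the number beyond the scatter remains open. Also open, from the compounds shown here alone, is whether a longer chain carrying the methanesulfonamido group would read differently.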